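The source may report more compounds than this note shows. Statements on the series, on what has been measured and on what is new or still open speak of the compounds shown alone.

Compound 1, `CCCCOC(=O)CCC(=O)N1CCN(CCCOc2cc3c(Nc4ccc(F)c(Cl)c4)ncnc3cc2OC)CC1`: 94.4%
Compound 2, `CCCCCOC(=O)CCC(=O)N1CCN(CCCOc2cc3c(Nc4ccc(F)c(Cl)c4)ncnc3cc2OC)CC1`: 87.1%
Compound 3, `CCCCCCCCCCOC(=O)CCC(=O)N1CCN(CCCOc2cc3c(Nc4ccc(F)c(Cl)c4)ncnc3cc2OC)CC1`: 95.7%

The three esters share one core and were compared in a functional assay on A549 cells (Homo sapiens) for cytotoxicity, read by MTT assay, with a stated time of 24 h, tested at 10 uM; a higher number here means a weaker effect of the compound at the concentration tested, a lower number a stronger effect. Compound 1 and compound 2 differ in a single place, (methyl in place of hydrogen on a saturated chain carbon, four bonds along the chain from an oxygen next to a carbonyl group), and the step between them is a number 7.3 percentage points lower from compound 1 to compound 2 (within the scatter). Compound 3 differs from compound 1 by hexyl in place of hydrogen on a saturated chain carbon, four bonds along the chain from an oxygen next to a carbonyl group, with a number 1.3 percentage points higher from compound 1 to compound 3 (within the scatter). Between compound 2 and compound 3 the step is a number 8.6 percentage points higher from compound 2 to compound 3 (within the scatter). All three numbers thus lie within the scatter of one another, and no one of them can be called weaker or stronger than the others.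

Compound 4, `CCCCCCCCCCCOC(=O)CCC(=O)N1CCN(CCCOc2cc3c(Nc4ccc(F)c(Cl)c4)ncnc3cc2OC)CC1`, has not yet been measured. It differs from compound 3 by methyl in place of hydrogen on a saturated chain carbon, ten or more bonds along the chain from an oxygen next to a carbonyl group. This is the same kind of change as from compound 1 to compound 2, but the place on the chain is not the same. The step from compound 3 to compound 4 in this assay is expected to be a number 2.7 percentage points lower from compound 3 to compound 4 (within the scatter), because the earlier step of a number 7.3 percentage points lower from compound 1 to compound 2 (within the scatter) stayed within the scatter and because a number 1.3 percentage points higher from compound 1 to compound 3 (within the scatter) shows that a much longer chain changed little. Compound 4 is therefore estimated at 93%, expected to fall between 83% and 100%.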

Compound 4, a percentage reported as activity, at one concentration (the size of the read-out at that concentration, not a potency): 93.4%
Compound 4: the middle estimate sits 0.4 percentage points below what was measured, within the range that was stated.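

In this assay, methyl at the far end of the long chain gives a number 2.3 percentage points lower from compound 3 to compound 4 (within the scatter), and beside the earlier methyl step on the shorter chain this reads: the same change on two cores in this assay, a number 7.3 percentage points lower (within the scatter) from compound 1 to compound 2 and a number 2.3 percentage points lower (within the scatter) from compound 3 to compound 4, 5 percentage points apart, within the scatter of two such steps

Hexyl, on the chain of compound 2, gives a number 6.3 percentage points higher from compound 2 to compound 4 (within the scatter), heptyl on the chain of compound 1 gives a number 1 percentage points lower from compound 1 to compound 4 (within the scatter), and the hexyl step set beside its earlier counterpart reads: the same change on two cores in this assay, a number 1.3 percentage points higher (within the scatter) from compound 1 to compound 3 and a number 6.3 percentage points higher (within the scatter) from compound 2 to compound 4, 5 percentage points apart, within the scatter of two such steps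

So in these esters, the same change made on a different chain length leaves the number within the scatter, but with every step that small, this does not show that any change has a real size that carries from one core to another, and it says nothing of cores beyond these four compounds.

The compounds shown vary only a plain alkyl ester chain, which leaves open how an amide in place of the ester, or an amine or a carboxylic acid at the chain end, would read. They also leave open whether any of these esters would separate from the others at a higher concentration or a longer time.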